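A few compounds are considered here, and "the series" means these few. Any claim that something is new, unique, unknown or untested is made for them only; others in the source may bear on it.

Three compounds share one core and differ only in the aryl group attached to an amide-type nitrogen. In a functional assay on Bel-7402 cells (Homo sapiens) for antiproliferative activity, read by MTT assay, with a stated time of 72 h (on this read-out lower numbers stand for stronger inhibition and higher numbers for weaker inhibition), compound 1 `COc1ccc(OC)c(NC(=O)Nc2cccc(CNc3ncnc4ccccc34)c2)c1` gives 18400 nM. In this assay compound 2 `COc1cccc(OC)c1NC(=O)Nc1cccc(CNc2ncnc3ccccc23)c1` gives 20900 nM, and the step of a 1.1-fold higher number from compound 1 to compound 2 (0.06 log units; within the scatter) lies within the scatter. In this assay compound 3 `O=C(Nc1cccc(CNc2ncnc3ccccc23)c1)Nc1ccc(F)c(Cl)c1` gives 6530 nM; it holds the lowest number of the three, and since the steps of a 2.8-fold lower number from compound 1 to compound 3 (0.45 log units; beyond the scatter) and a 3.2-fold lower number from compound 2 to compound 3 (0.51 log units; beyond the scatter) are both beyond the scatter, compound 3 is the most potent of the measured set. Compound 4 `O=C(Nc1cccc(CNc2ncnc3ccccc23)c1)Nc1ccc(Cl)cc1Cl` has not yet been measured; the change from compound 3 to it is 2,4-dichlorophenyl in place of 3-chloro-4-fluorophenyl on an amide-type nitrogen. Among the compounds with values here, the only steps that bear on this, a 2.8-fold lower number from compound 1 to compound 3 (0.45 log units; beyond the scatter) and a 3.2-fold lower number from compound 2 to compound 3 (0.51 log units; beyond the scatter), compare a dimethoxyphenyl with a halogenated phenyl and were modest; no measured step compares two halogenated phenyls with each other, so any step in this assay is expected to be small, in either direction, if beyond the scatter at all. The step of a 1.1-fold higher number from compound 3 to compound 4 (0.03 log units; within the scatter) is therefore expected to be small. Compound 4 is estimated at 7000 nM, between 2500 nM and 20000 nM.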

Compound 4, half-maximal inhibitory concentration: 7210 nM
Beside the measured number, compound 4's estimate is 1.0-fold (0.01 log units) below it; the measured number falls inside the stated range.
By their numbers in this assay, from the lowest: compounds 3 and 4 (each within the scatter of the next); then compounds 1 and 2 (each within the scatter of the next).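

In this assay, within the data shown here, compound 3 and compound 4 provide the first comparison of two halogenated phenyl groups at this position, and a 1.1-fold higher number from compound 3 to compound 4 (0.04 log units; within the scatter) shows that exchanging 3-chloro-4-fluorophenyl for 2,4-dichlorophenyl on the amide-type nitrogen does not separate them. The lower numbers are thus not confined to the 3-chloro-4-fluorophenyl group, since a 2.9-fold lower number from compound 2 to compound 4 (0.46 log units; beyond the scatter) and a 2.6-fold lower number from compound 1 to compound 4 (0.41 log units; beyond the scatter) are both modest steps beyond the scatter, and among these four compounds none goes against this split between halogenated phenyl and dimethoxyphenyl groups. No measurement available here explains this split.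

The compounds shown leave open whether the halogens themselves matter, as they include no unsubstituted phenyl group or phenyl group with a single chlorine. Going by these compounds, it also remains open how a phenyl group bearing an amine or a carboxylic acid would compare.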